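The compounds below may be only part of what the source reports. "The series", "measured", "known", "first", "only" and "open" are said of these compounds alone.

Measured so far in a functional assay on HCT-15 cells (Homo sapiens) for inhibition, read by sulforhodamine B assay, with a stated time of 48 h; a lower number here means a stronger inhibitor of growth, a higher number a weaker inhibitor of growth:

- compound 1 `Nc1cc(N)c2nc(-c3ccccc3)c(NCc3ccc(Cl)c(Cl)c3)nc2c1`: < 100000 nM
- compound 2 `CCOC(=O)[C@H](CCC(=O)O)NC(=O)c1ccc(Oc2nc3cc(N)cc(N)c3nc2-c2ccccc2)cc1`: < 100000 nM
- compound 3 `CCOC(=O)[C@H](CCC(=O)O)NC(=O)c1ccc(CNc2nc3cc(N)cc(N)c3nc2-c2ccccc2)cc1`: < 100000 nM

The value of compound 1, < 100000 nM, is a limit of the assay, not a measured number. For compound 2 the value < 100000 nM is likewise a limit. For compound 3 the value < 100000 nM is also a limit. So compound 1 cannot be placed anywhere definite among the numbers shown: the limit of < 100000 nM in this assay, at which 3 of the 3 values shown sit, and nothing separates the three compounds from one another.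

Compound 4 `Nc1cc(N)c2nc(-c3ccccc3)c(NCc3ccc(F)cc3)nc2c1` differs from compound 1 in one place: 4-fluorophenyl in place of 3,4-dichlorophenyl on a saturated chain carbon bound to a nitrogen on an aromatic ring. Among the compounds with values here, since no step between two measured compounds has been recorded in this assay, there is no basis for expecting a step of any particular size or direction; the expectation is for no change beyond the usual scatter. On that basis compound 4 is expected to give about 30000 nM in this assay, within a range from 5000 nM to 100000 nM, and the step that the limit leaves unreadable from compound 1 to compound 4 is estimated to stay within scatter, with a real chance that only a limit is again reported.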

Compound 4, concentration for total growth inhibition: 19100 nM
Estimate against measurement, compound 4: 1.6-fold (0.20 log units) above; the measured number falls inside the stated range.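

In this assay compound 1 gives < 100000 nM as a limit, not a number. Within the data shown here, no step from compound 1 to compound 4 can therefore be read. As far as these compounds go, what stays open is whether 4-fluorobenzyl in place of 3,4-dichlorobenzyl changes growth inhibition at all, and in which direction.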